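Cytotoxicity limits across a small thienyl-indole amide series

A few compounds are considered here, and "the series" means these few. Any claim that something is new, unique, unknown or untested is made for them only; others in the source may bear on it.

Compound 1 `COc1ccc(Cn2c(C(=O)N3CCN(Cc4ccccc4)CC3)cc3sc(CNC(C)c4ccccc4)cc32)cc1` is the reference. In an ADME assay on HEK-293T cells (Homo sapiens) for cytotoxicity, read by luminescence, with a stated time of 24 h (on this read-out higher numbers stand for lower toxicity in this test and lower numbers for higher toxicity in this test), compound 1 reaches only the assay limit, > 100000 nM. Compound 2 `COc1ccc(Cn2c(C(=O)N3CCN(Cc4ccccc4)CC3)cc3sc(COCc4ccccc4)cc32)cc1` carries benzyloxy in place of (1-phenylethyl)amino on a saturated chain carbon bound to an aromatic carbon. In this assay compound 2 likewise stops at the limit, > 100000 nM. The step that the two limits leave unreadable from compound 1 to compound 2 therefore cannot be sized, because every value stands at the limit of > 100000 nM in this assay, at which 3 of the 3 values shown sit.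

Compound 3 `COc1ccc(Cn2c(C(=O)N3CCN(Cc4ccccc4)CC3)c(CNC(C)c3ccccc3)c3sccc32)cc1` has the same atoms as compound 1 joined differently; the difference between the two cores is not broken down here. In this assay compound 3 also returns only the limit, > 100000 nM.

Compound 4 `COc1ccc(Cn2c(C(=O)N3CCN(Cc4ccccc4)CC3)c(COCc3ccccc3)c3sccc32)cc1` is not yet measured. It differs from compound 3 by benzyloxy in place of (1-phenylethyl)amino on a saturated chain carbon bound to an aromatic carbon, the same change, at the same place, as that from compound 1 to compound 2. Since that measured step left both partners at the limit, compound 4 is expected to show a step that the limit leaves unreadable from compound 3 to compound 4 in this assay, again most likely reported only as a limit. The estimate for compound 4 in this assay is accordingly 150000 nM, with a range from 60000 nM to 400000 nM.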

Compound 4, half-maximal cytotoxic concentration: > 100000 nM
Compound 4: only a limit was reported; the forecaster's own chance of this, stated with the estimate: 85%; the middle value does not contradict the limit.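

No step can be read from compound 3 to compound 4, because both compounds stop at a limit in this assay: the limit of > 100000 nM in this assay, at which 4 of the 4 values shown sit.

The compounds shown leave open whether benzyloxy in place of (1-phenylethyl)amino changes the half-maximal cytotoxic concentration on either core, and whether the two cores differ at all.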